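This account rests on a few compounds, and the source may have more. Where it says the series, first, only, none or still open, it means among the compounds named here.

Measured in an ADME assay on L929 cells (Mus musculus) for cytotoxicity, read by resazurin assay, with a stated time of 72 h (on this read-out lower numbers stand for stronger inhibition and higher numbers for weaker inhibition), both values being limits:
- compound 1 `O=C(/C=C/c1ccc2c(c1)B(O)OC2)c1ccccn1`: > 10 ug/mL
- compound 2 `O=C(/C=C/c1ccc2c(c1)B(O)OC2)c1ccc(Br)cc1`: > 10 ug/mL

Compound 2 stands only at its limit of > 10 ug/mL, with no number behind it. Compound 3 `Cn1cccc1C(=O)/C=C/c1ccc2c(c1)B(O)OC2` differs from compound 2 by the change (1-methyl-1H-pyrrol-2-yl in place of 4-bromophenyl on a carbonyl carbon). Among the measured compounds shown here, the one measured step at this place on a carbonyl carbon is a step that the two limits leave unreadable from compound 1 to compound 2, so it gives no size. The remaining evidence is the limit of > 10 ug/mL in this assay, at which 2 of the 2 values shown sit. No direction follows from these, and no change beyond the scatter is expected in this assay. The expected step is a step that the limit leaves unreadable from compound 2 to compound 3. Estimated for compound 3: 14 ug/mL, with an expected range of 6 ug/mL to 40 ug/mL.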

Compound 3, half-maximal inhibitory concentration: > 10 ug/mL
Compound 3 ended at the assay's limit; the forecaster's own chance of this, stated with the estimate: 75%; the middle value is on the limit's open side.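

No step can be read among compound 1, compound 2 and compound 3 in this assay, since all three rest at a limit: the limit of > 10 ug/mL in this assay, at which 3 of the 3 values shown sit.

The compounds shown leave open whether pyridin-2-yl, 4-bromophenyl or 1-methyl-1H-pyrrol-2-yl on the carbonyl carbon makes any difference past that limit.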